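Methylating the pyrazole nitrogen in a kinase inhibitor series

A few compounds are considered here, and "the series" means these few. Any claim that something is new, unique, unknown or untested is made for them only; others in the source may bear on it.

Of the compounds shown here, two have been measured. Compound 1 `Cc1[nH]ncc1-c1cncc(-c2ccc(C(N)=O)c(OC(C)C)c2)c1` gives 16 nM in an assay on cells for inhibition of MAP kinase-interacting serine/threonine-protein kinase 2 (Homo sapiens), read by mobility shift assay, with stated times of 10 min and 60 min, in the presence of a further agent that is not named here; on this read-out higher numbers stand for weaker inhibition and lower numbers for stronger inhibition. Compound 2 `Cc1n[nH]c(C)c1-c1cncc(-c2ccc(C(N)=O)c(OC(C)C)c2)c1` gives 14 nM in this assay, the lowest of the two numbers, though the step from compound 1 to compound 2 was a 1.1-fold lower number from compound 1 to compound 2 (0.06 log units; within the scatter), so the two stand level. Compound 3 `Cc1c(-c2cncc(-c3ccc(C(N)=O)c(OC(C)C)c3)c2)cnn1C` is not yet measured. It differs from compound 2 in one place: 1,5-dimethyl-1H-pyrazol-4-yl in place of 3,5-dimethyl-1H-pyrazol-4-yl on an aromatic carbon. Among the measured compounds shown here, the only measured step concerns a methyl added to a ring carbon and gave no change beyond the scatter; no measured step removes the hydrogen-bond donor of the pyrazole, so that step carries no direct precedent. The expectation for compound 3 is therefore uncertain, with a modest rise in the number allowed for, giving an expected step of a 2.9-fold higher number from compound 2 to compound 3 (0.46 log units; beyond the scatter). Compound 3 is estimated at 40 nM, within a range from 12 nM to 130 nM.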

Compound 3, half-maximal inhibitory concentration in the MAP kinase-interacting serine/threonine-protein kinase 2 assay: 120 nM
Compound 3: the middle estimate sits 3.0-fold (0.48 log units) below what was measured; measured number inside the range.
By their numbers in the MAP kinase-interacting serine/threonine-protein kinase 2 assay, from the lowest: compounds 2 and 1 (each within the scatter of the next); then compound 3.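

In the MAP kinase-interacting serine/threonine-protein kinase 2 assay compound 3 gives 120 nM; placing the methyl on the ring nitrogen rather than on a ring carbon, with 1,5-dimethyl-1H-pyrazol-4-yl in place of 3,5-dimethyl-1H-pyrazol-4-yl, gives an 8.6-fold higher number from compound 2 to compound 3 (0.93 log units; beyond the scatter), and adding that methyl to the nitrogen alone gives a 7.5-fold higher number from compound 1 to compound 3 (0.88 log units; beyond the scatter). Unlike the earlier methyl on a ring carbon, this one moves the number beyond the scatter, so at this position it matters where the methyl sits, whereas in a physicochemical assay for solubility, measured as thermodynamic solubility, at pH 7.4 (a lower number here means a less soluble compound, a higher number a more soluble compound), the same swap gives only a 1.4-fold lower number from compound 2 to compound 3 (0.14 log units; within the scatter). In the physicochemical assay compound 2 gives 10 ug/mL and compound 3 gives 7.3 ug/mL. The entering group has 0 hydrogen-bond donors where the leaving group has 1, but nothing here shows that this difference explains the weaker inhibition.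

As far as these compounds go, what remains open is how a larger group on that nitrogen, such as an ethyl or a 2-aminoethyl chain, would read in the MAP kinase-interacting serine/threonine-protein kinase 2 assay. A methyl alone cannot show whether any substituent there gives a similar rise.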